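Permeability across a hydroxy-acyl series on a shared core

The source may hold more compounds than are shown below. What is called first, only, known or untested is meant among the compounds shown, and "the series" means these compounds.

Measured compounds:
- compound 1, `O=C(NCc1cc(Cl)ccc1-n1cnnn1)[C@@H]1C[C@@H]2C[C@@H]2N1C(=O)[C@H](O)Cc1ccccn1`: 1.2 10^-6 cm/s
- compound 2, `CCCC[C@@H](O)C(=O)N1N=CC[C@H]1C(=O)NCc1cc(Cl)ccc1-n1cnnn1`: 9.8 10^-6 cm/s
- compound 3, `CC1(C[C@@H](O)C(=O)N2C[C@H]3C[C@H]3[C@H]2C(=O)NCc2cc(Cl)ccc2-n2cnnn2)CC1`: 2.2 10^-6 cm/s

In an ADME assay on Caco-2 cells (Homo sapiens) for permeability, read by LC-MS, in the apical to basolateral direction, with a stated time of 60 min, at pH 6.5 (a higher number here means that the compound crosses the layer faster, a lower number that the compound crosses the layer more slowly), compound 2 stands highest of the three, its nearest neighbour being compound 3, whose number is lower by a margin beyond the scatter, and its furthest compound 1, lower still. Compound 1 and compound 3 each carry a different ring-bearing side chain and a different core from compound 2, so no single-point comparison among the measured compounds is available.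

Compound 4, `O=C(NCc1cc(Cl)ccc1-n1cnnn1)[C@@H]1CC=NN1C(=O)[C@H](O)c1ccccc1F`, is not yet measured. It differs from compound 2 in one place: 2-fluorophenyl in place of butyl on a saturated chain carbon bound to a carbonyl carbon and an oxygen on a saturated carbon. Within the data shown here, with no measured pair isolating this kind of change, the expectation for compound 4 leans on the value of compound 2 alone, 9.8 10^-6 cm/s, and the step from compound 2 to compound 4 is expected to be small, at most a modest drop, and possibly none beyond the scatter: a 1.4-fold lower number from compound 2 to compound 4 (0.15 log units; within the scatter). Compound 4 is therefore estimated at 7 10^-6 cm/s, within a range of 3 10^-6 cm/s to 15 10^-6 cm/s.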

Compound 4, apparent permeability: 8.9 10^-6 cm/s
Estimate against measurement, compound 4: 1.3-fold (0.10 log units) below; the measured number falls inside the stated range.
By their numbers in this assay, from the lowest: compounds 1 and 3 (each within the scatter of the next); then compounds 4 and 2 (each within the scatter of the next).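

In this assay, placing 2-fluorophenyl in place of butyl on a saturated chain carbon bound to a carbonyl carbon and an oxygen on a saturated carbon gives a 1.1-fold lower number from compound 2 to compound 4 (0.04 log units; within the scatter), which lies within the scatter. This is the only comparison shown that isolates one place, and it indicates that, on this core, a chain and an aromatic ring at this position give numbers this read-out cannot tell apart. No supporting data bear on why the two numbers agree.

From the compounds shown here alone, whether an amine, a carboxylic acid or a longer chain at this position would give a number in the same range remains open. Going by these compounds, it is also open whether the same exchange would leave the number unmoved on the core of compound 1 or the core of compound 3.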